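Dropping the Methoxy Group: Expected Paw Edema Inhibition

The source may report more compounds than this note shows. Statements on the series, on what has been measured and on what is new or still open speak of the compounds shown alone.

Compound 1, `Clc1ccc([C@H]2CC(c3ccccc3)=NN2c2ncc(Br)cn2)cc1`: 61%
Compound 2, `Brc1ccc([C@H]2CC(c3ccccc3)=NN2c2ncc(Br)cn2)cc1`: 64%
Compound 3, `COc1ccc([C@H]2CC(c3ccc(Cl)cc3)=NN2c2ncc(Br)cn2)cc1`: 58%

In a functional assay on the whole organism (strain Wistar albino) for inhibition, with Rattus norvegicus as the target, read by paw edema, with stated times of 30 min and 0.5 h, at a dose of 20 mg/kg (a lower number here means less inhibition, a higher number more inhibition at the dose given (going by the name of the read-out)), compound 3 gives 58%, the lowest of the three numbers, though compound 1 with 61% and compound 2 with 64% both lie within the scatter of it. The three measured values thus sit close together, and no measured difference separates them.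

Compound 4, `Clc1ccc(C2=NN(c3ncc(Br)cn3)[C@@H](c3ccccc3)C2)cc1`, is reached from compound 3 by one change: hydrogen in place of methoxy on an aromatic carbon. Within the data shown here, the only measured step of a single change, a number 3 percentage points higher from compound 1 to compound 2 (within the scatter), concerns a different swap on an aromatic carbon and did not move the read-out beyond the scatter. Among the measured compounds shown here, no measured pair shows what hydrogen in place of methoxy does here, so the expectation rests on the narrow spread of the three known values. Compound 4 is therefore expected to show a number 2 percentage points higher from compound 3 to compound 4 (within the scatter), a step of no real size beyond the scatter. Compound 4 is estimated at 60%, with a range from 50% to 70%.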

Compound 4, a percentage reported as inhibition, in the whole organism at one dose (the size of the read-out at that dose, not a potency): 60%
Compound 4: the middle estimate sits on the measured number at the digits printed, within the range that was stated.
By their numbers in this assay, from the lowest: compounds 3, 4, 1 and 2 (each within the scatter of the next).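

Hydrogen in place of methoxy gives a number 2 percentage points higher from compound 3 to compound 4 (within the scatter) in this assay, and this is the first single change shown on this aromatic carbon, para to a large group. Going from 4-methoxyphenyl to phenyl therefore leaves no measurable mark on the inhibition at this dose, so the methoxy group is not required for the read-out to stay in this range. Nothing available explains this result.

The compounds shown leave open whether a different group at this place, such as an amine, a carboxylic acid or a longer alkoxy chain, would move the read-out beyond the scatter. They also leave open whether the 4-methoxyphenyl and phenyl forms would remain indistinguishable at other doses, as a single dose gives no measure of potency.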